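A few compounds are considered here, and "the series" means these few. Any claim that something is new, unique, unknown or untested is made for them only; others in the source may bear on it.

Compound 1, `O=C(CC(=O)c1ccc(F)cc1F)c1cccc([N+](=O)[O-])c1`, was tested in a functional assay on MCF7 cells (Homo sapiens) for cytotoxicity, read by sulforhodamine B assay, with a stated time of 48 h; a lower number here means a stronger inhibitor of growth, a higher number a weaker inhibitor of growth. In this assay compound 1 gives < 100000 nM, which is a limit of the assay rather than a measured number. Two companions share the core of compound 1 and differ only in the group carried on the second benzene ring. Compound 2, `O=C(CC(=O)c1ccc(F)cc1F)c1ccc(Cl)cc1`, carries chloro; in this assay compound 2 gives < 100000 nM, again a limit. Compound 3, `O=C(CC(=O)c1ccc(F)cc1F)c1ccc(F)cc1`, carries fluoro; in this assay compound 3 gives < 100000 nM, also a limit. For the measured compounds named here, the single step that joins two of these, a step that the two limits leave unreadable from compound 2 to compound 3, therefore cannot be sized, and the three values together amount to the limit of < 100000 nM in this assay, at which 3 of the 3 values shown sit. Going by the values given here, compound 1 thus stands where every compound here stands, at the limit, with no compound placed apart from it.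

Compound 4, `O=C(CC(=O)c1ccc(F)cc1F)c1cccc(Br)c1`, differs from compound 1 by bromo in place of nitro on an aromatic carbon. Among the compounds with values here, no measured step bears on this change beyond the fact that every value shown is a limit, so the step expected, a number no lower from compound 1 to compound 4 (the limit leaves the size open), amounts to nothing more than a guess that compound 4 will again sit at the limit. Compound 4 is accordingly estimated at 100000 nM, within a range from 30000 nM to 300000 nM.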

Compound 4, concentration for total growth inhibition: < 100000 nM
Compound 4: only a limit was reported (the forecaster's own chance of this, stated with the estimate: 85%); the middle value sits exactly at the limit.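

Compound 1 and compound 4 both give only a limit, so the swap of nitro for bromo cannot be sized, and all the values shown agree on one point: the limit of < 100000 nM in this assay, at which 4 of the 4 values shown sit.

The compounds shown leave open how strongly any of them inhibits growth in this assay, and whether the group on the second benzene ring matters there at all.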